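Compound 3: methoxypyrimidine in place of the aryl group

A few compounds are considered here, and "the series" means these few. Any claim that something is new, unique, unknown or untested is made for them only; others in the source may bear on it.

In a functional assay on PANC-1 cells (Homo sapiens), read by microscopy, crystal violet staining and transwell migration, with a stated time of 18 h, in the presence of a further agent that is not named here (on this read-out higher numbers stand for weaker inhibition and lower numbers for stronger inhibition), compound 1 `CCc1nc(-c2ccc(OC)cc2)n(-c2cccc(C(=O)NCCCCc3ccccc3)c2)n1` gives 140 nM and compound 2 `CCc1nc(-c2ccc(OC(F)(F)F)cc2)n(-c2cccc(C(=O)NCCCCc3ccccc3)c2)n1` gives 640 nM, the higher of the two numbers. Compound 3 `CCc1nc(-c2ncc(OC)cn2)n(-c2cccc(C(=O)NCCCCc3ccccc3)c2)n1` carries 5-methoxypyrimidin-2-yl in place of 4-(trifluoromethoxy)phenyl on an aromatic carbon. For the measured compounds named here, one measured step bears on this, a modest one beyond the scatter (a 4.6-fold higher number from compound 1 to compound 2 (0.66 log units; beyond the scatter)), and it changes only the group on oxygen. Going by the values given here, no measured step covers a ring exchange. The expected move in this assay is small, leans toward a lower number and stays within the scatter (a 1.6-fold lower number from compound 2 to compound 3 (0.20 log units; within the scatter)). Compound 3 is estimated at 400 nM (expected range 120 nM to 1400 nM).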

Compound 3, half-maximal inhibitory concentration: 110 nM
Estimate against measurement, compound 3: 3.6-fold (0.56 log units) above; measured number below the stated range.
By their numbers in this assay, from the lowest: compounds 3 and 1 (each within the scatter of the next); then compound 2.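

In this assay, for the compounds shown here, a ring with two hetero atoms is accepted on this aromatic carbon, a ring exchange that no earlier step covered: a 5.8-fold lower number from compound 2 to compound 3 (0.76 log units; beyond the scatter) for 5-methoxypyrimidin-2-yl in place of 4-(trifluoromethoxy)phenyl, and a 1.3-fold lower number from compound 1 to compound 3 (0.10 log units; within the scatter) for the same group in place of 4-methoxyphenyl. Among these compounds, only compound 2 stands apart from the other two, and the two methoxy-bearing aryl groups cannot be told apart. No supporting data bear on why this exchange is tolerated.

Open, as far as these compounds go, is whether both ring nitrogens matter, which 5-methoxypyridin-2-yl would test, and whether the methoxy group on the pyrimidine can give way to an amine.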